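The source may report more compounds than this note shows. Statements on the series, on what has been measured and on what is new or still open speak of the compounds shown alone.

Measured compounds in an assay on isolated protein for inhibition of DNA topoisomerase 1 (Homo sapiens), with a stated time of 30 min, tested at 100 uM; a lower number here means a weaker effect, a higher number a stronger effect of the compound at the concentration tested:

Compound 1, `Cc1ccc2nc(-c3ccccc3N(C)C)[nH]c(=O)c2c1` — 82.9%
Compound 2, `Cc1ccc2c(=O)[nH]c(-c3ccccc3C)nc2c1` — 100%
Compound 3, `Cc1ccc2c(=O)[nH]c(-c3ccccc3OC(F)(F)F)nc2c1` — 100%

Compound 3 stands level with compound 2 at the digits printed, the two together giving the highest of the three numbers in this assay. Compound 1, with the dimethylamino group in place of a methyl, lies a number of percentage points lower, beyond the scatter, and is the furthest of the set from compound 3.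

Compound 4, `Cc1ccc2c(=O)[nH]c(-c3ccccc3F)nc2c1`, is not yet measured. Its change from compound 3 is fluoro in place of trifluoromethoxy on an aromatic carbon. Within the data shown here, the only measured step that bears on it is no change at the digits printed from compound 2 to compound 3 (within the scatter): swapping methyl for trifluoromethoxy at the same aromatic carbon left this assay unchanged within the scatter. A swap of trifluoromethoxy for fluoro at that carbon is therefore expected to show no step beyond the scatter, so the expected step is a number 4 percentage points lower from compound 3 to compound 4 (within the scatter). Compound 4 is estimated to give 96% in this assay, within the range 82% to 100%.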

Compound 4, a percentage reported as inhibition, at one concentration (the size of the read-out at that concentration, not a potency): 81.2%
Compound 4: middle estimate off by 14.8 percentage points, on the high side, outside the stated range (below it).
By their numbers in this assay, from the lowest: compounds 4 and 1 (each within the scatter of the next); then compounds 2 and 3 (each within the scatter of the next).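

At this aromatic carbon, this assay does respond to the group: the swap to fluoro gives a number 18.8 percentage points lower from compound 3 to compound 4 (beyond the scatter) and the same swap from methyl gives a number 18.8 percentage points lower from compound 2 to compound 4 (beyond the scatter) in a series where methyl and trifluoromethoxy could not be told apart. Among these compounds, the position is therefore not indifferent to substitution, and the earlier step alone gave no sign of this, with fluoro the only group of the three that separates from the others. Nothing measured here speaks to why the value falls with fluoro.

A read-out at one concentration is not a potency, so any difference between compound 2 and compound 3 at their shared top value stays unresolved. Going by these compounds, whether chloro, methoxy or a carboxylic acid at this carbon would track fluoro or methyl remains open.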